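A Bromo Added to Compound 2

This account rests on a few compounds, and the source may have more. Where it says the series, first, only, none or still open, it means among the compounds named here.

In a functional assay on HeLa cells (Homo sapiens) for cytotoxicity, read by MTT assay, with a stated time of 48 h (on this read-out higher numbers stand for weaker inhibition and lower numbers for stronger inhibition), compound 1 (`COc1cc(-c2ocnc2-c2cc(Br)c(OC)c(OC)c2)ccc1SC`) gives 440 nM and compound 2 (`COc1cc(-c2ocnc2-c2cc(OC)c(OC)c(OC)c2)ccc1SC`) gives 645 nM. The measured step between them, a 1.5-fold higher number from compound 1 to compound 2 (0.17 log units; within the scatter), leaves the two compounds level in practice, so compound 2 holds no clear rank. Compound 3 (`COc1cc(-c2ncoc2-c2cc(Br)c(SC)c(OC)c2)cc(OC)c1OC`) has bromo in place of hydrogen on an aromatic carbon, ortho to a methylsulfanyl group: bromo in place of hydrogen on an aromatic carbon. For the measured compounds named here, only that one measured step bears on this change, and only loosely, since it exchanges bromo for methoxy at a different place and does not add a group in place of hydrogen. Going by the values given here, no measured pair shows this exact change, so a modest weakening in this assay is only a cautious expectation. The estimated change is a 1.6-fold higher number from compound 2 to compound 3 (0.19 log units; within the scatter). For compound 3 the expected value is 1000 nM, with an estimated range of 200 nM to 5000 nM.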

Compound 3, half-maximal inhibitory concentration: > 20000 nM
Compound 3: a limit, no number (the forecaster's own chance of this, stated with the estimate: 10%); at least 20-fold (1.30 log units) between middle value and limit.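

In this assay, adding one bromo to an aromatic carbon, ortho to a methylsulfanyl group, gives an at least 31-fold higher number from compound 2 to compound 3 (1.49 log units; beyond the scatter) and so marks this place as highly sensitive to the change. The earlier step, which exchanged bromo for methoxy at a different place, stayed within the scatter, so it gave no sign that a single atom could matter this much. The value for compound 3 is a limit of the assay and not a number, so the full size of the loss stays unknown: the limit of > 20000 nM in this assay, at which 1 of the 3 values shown sits.

The compounds shown leave open whether any other group at this place, such as fluoro, methyl or an amine, would keep the activity of compound 2. They also do not tell why bromo has this effect here.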